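A few compounds are considered here, and "the series" means these few. Any claim that something is new, unique, unknown or untested is made for them only; others in the source may bear on it.

Compound 3 `O=C(OC[C@H]1CN(c2ccc(-n3cc(-c4ccccn4)cn3)c(F)c2)C(=O)O1)c1ccccc1` stands at the ceiling of an ADME assay on HEK293-A cells (Homo sapiens) for cytotoxicity, read by MTT assay, with a stated time of 48 h; a higher number here means a weaker inhibitor, a lower number a stronger inhibitor: compound 3 gives > 400 ug/mL, which is a limit, not a number. Compound 1 `O=C1O[C@@H](CO)CN1c1ccc(-n2cc(-c3ccccn3)cn2)c(F)c1` also gives a limit, > 400 ug/mL in this assay. Compound 2 `O=C1CSC(=O)N1C[C@H]1CN(c2ccc(-n3cc(-c4ccccn4)cn3)c(F)c2)C(=O)O1` gives 283 ug/mL in this assay. The steps of an at least 1.4-fold lower number from compound 1 to compound 2 (0.15 log units; that floor lies within the scatter) and an at least 1.4-fold higher number from compound 2 to compound 3 (0.15 log units; that floor lies within the scatter) are both floored by that limit, and a step that the two limits leave unreadable from compound 1 to compound 3 cannot be read; the limit of > 400 ug/mL in this assay, at which 2 of the 3 values shown sit, frames all three. Compound 4 `O=C1O[C@@H](Cn2ccnc2)CN1c1ccc(-n2cc(-c3ccccn3)cn2)c(F)c1` carries 1H-imidazol-1-yl in place of benzoyloxy on a saturated chain carbon bound to a saturated ring carbon. Among the measured compounds shown here, no measured step exchanges one aromatic group for another on that chain carbon, so the only guide is that the whole series stays near the limit. The step of an at least 1.1-fold lower number from compound 3 to compound 4 (0.05 log units; that floor lies within the scatter) is expected to lie within the scatter. Compound 4 is expected at 350 ug/mL, between 120 ug/mL and 400 ug/mL.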

Compound 4, half-maximal inhibitory concentration: > 400 ug/mL
Compound 4 gave a limit, no number (the forecaster's own chance of this, stated with the estimate: 55%); middle value at least 1.1-fold (0.05 log units) from the limit.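

Compound 4 shows that 1H-imidazol-1-yl, on a saturated chain carbon bound to a saturated ring carbon, also leaves the read-out at a limit: the limit of > 400 ug/mL in this assay, at which 3 of the 4 values shown sit. Among the compounds shown here, the one step with a floor is an at least 1.4-fold higher number from compound 2 to compound 4 (0.15 log units; that floor lies within the scatter), and that floor does not separate the two. The steps from compound 3 and from compound 1 to compound 4 cannot be read.

From the compounds shown here alone, whether a primary amine or a carboxylic acid on this chain carbon would give a number rather than a limit stays open. Going by these compounds, how far the compounds at the limit differ from one another also stays open.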